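The source may report more compounds than this note shows. Statements on the series, on what has been measured and on what is new or still open speak of the compounds shown alone.

Working notes on the series. Three compounds have numbers in a functional assay on BE(2)-C cells (Homo sapiens) for inhibition, read by MTT assay, with a stated time of 72 h; on this read-out higher numbers stand for weaker inhibition of growth and lower numbers for stronger inhibition of growth. Compound 1, `N#C/C(=C\c1ccc(Cl)cc1)C(=O)c1ccc[nH]1`, gives 34000 nM in this assay. Compound 2, `N#C/C(=C\c1c(F)c(F)c(F)c(F)c1F)C(=O)c1c[nH]c2ccccc12`, gives 10000 nM in this assay. Compound 3, `COc1ccc(CNC(=O)/C(C#N)=C/c2ccc[nH]2)cc1`, gives 47000 nM in this assay. Compound 3 stands at the highest of the three numbers; its number and that of compound 1 lie within the scatter of each other, so no order between compound 3 and compound 1 is claimed, whereas the number for compound 2 is lower than that for compound 3 by a margin beyond the scatter. No two of the measured compounds differ in only one place, so no single-step comparison is available among them.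

Compound 4, `COc1ccc(CNC(=O)/C(C#N)=C/c2ccc(Cl)o2)cc1`, has not yet been measured in this assay. It is compound 3 with 5-chlorofuran-2-yl in place of 1H-pyrrol-2-yl on a double-bonded chain carbon bound to a double-bonded chain carbon. Within the data shown here, with no measured pair to anchor this kind of exchange, the expectation is for a small step from compound 3 to compound 4, if any, and not one reliably beyond the scatter; the direction, if there is one, is expected toward a lower number, a 1.6-fold lower number from compound 3 to compound 4 (0.19 log units; within the scatter). For compound 4 the estimate in this assay is 30000 nM, with a range from 10000 nM to 90000 nM.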

Compound 4, concentration for 50% growth inhibition: 11000 nM
The estimate for compound 4 lay 2.7-fold (0.44 log units) above the measured number; measured number inside the range.
By their numbers in this assay, from the lowest: compounds 2 and 4 (each within the scatter of the next); then compounds 1 and 3 (each within the scatter of the next).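

In this assay, among these compounds, the exchange of 1H-pyrrol-2-yl for 5-chlorofuran-2-yl on a double-bonded chain carbon bound to a double-bonded chain carbon gives a 4.3-fold lower number from compound 3 to compound 4 (0.63 log units; beyond the scatter) and so shows that the number responds to a change at this place with the rest of the structure held fixed, which the earlier compounds, none differing in only one place, could not show. The exchange alters several things at once: the ring nitrogen with its hydrogen-bond donor leaves, while a ring oxygen counted as a hydrogen-bond acceptor and a chlorine enter, so this single step cannot be divided among those changes. Nothing at hand bears on the reason for the step.

The compounds shown leave open whether the chlorine or the change of ring carries the step, a question that furan-2-yl or 5-chloro-1H-pyrrol-2-yl at the same place would separate. Also open, as far as these compounds go, is whether 5-bromofuran-2-yl or 5-methylfuran-2-yl would behave like 5-chlorofuran-2-yl, and whether the same exchange would give a step of like size on the core of compound 1.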